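Swapping a Chlorophenyl for a Hydroxyphenyl on the Urea

This account rests on a few compounds, and the source may have more. Where it says the series, first, only, none or still open, it means among the compounds named here.

Of the compounds shown here, three built on one shared core have been measured in a functional assay on SW-620 cells (Homo sapiens) for inhibition, read by MTT assay, with a stated time of 72 h; a lower number here means a stronger inhibitor, a higher number a weaker inhibitor. Compound 1 `COc1cc(NC(C)CCCNC(=O)Nc2cccc(F)c2)c2ncccc2c1` gives 27000 nM. Compound 2 `COc1cc(NC(C)CCCNC(=O)Nc2cccc(Cl)c2)c2ncccc2c1` gives 26000 nM. Compound 3 `COc1cc(NC(C)CCCNC(=O)Nc2cccc(C(F)(F)F)c2)c2ncccc2c1` gives 22000 nM. On the numbers shown, compound 2 sits with compound 1 on one side and compound 3 on the other, and every gap is within the scatter: the step of a 1.0-fold lower number from compound 1 to compound 2 (0.02 log units; within the scatter), the step of a 1.2-fold lower number from compound 2 to compound 3 (0.07 log units; within the scatter) and the step of a 1.2-fold lower number from compound 1 to compound 3 (0.09 log units; within the scatter) all fall inside it. Each of these steps exchanged one substituent for another on an aromatic carbon, and none moved this assay beyond its noise.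

Compound 4 `COc1cc(NC(C)CCCNC(=O)Nc2ccc(O)cc2)c2ncccc2c1` has not yet been measured. It differs from compound 2 in one place: 4-hydroxyphenyl in place of 3-chlorophenyl on an amide-type nitrogen. The measured steps bear on it only loosely: they changed the group on that ring, but none introduced a hydrogen-bond donor or acceptor. With all three steps within the scatter, the expectation for this assay is a step of a 1.2-fold higher number from compound 2 to compound 4 (0.06 log units; within the scatter), none beyond the scatter or at most a slight one. Compound 4 is therefore estimated at about 30000 nM. Within the data shown here, the expected range for compound 4 runs from 12000 nM to 75000 nM, set wide, as no measured compound carries a 4-hydroxyphenyl.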

Compound 4, half-maximal inhibitory concentration: 30000 nM
The estimate for compound 4 equals the measured number at the digits printed; the range from low to high includes it.
By their numbers in this assay, from the lowest: compounds 3, 2, 1 and 4 (each within the scatter of the next).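

In this assay, exchanging the whole aryl group on the amide-type nitrogen moves nothing beyond the scatter: this holds for the step of a 1.2-fold higher number from compound 2 to compound 4 (0.06 log units; within the scatter) and the step of a 1.4-fold higher number from compound 3 to compound 4 (0.13 log units; within the scatter) and the step of a 1.1-fold higher number from compound 1 to compound 4 (0.05 log units; within the scatter) alike. The earlier compounds shown here varied only a halogen or trifluoromethyl group on a ring with 0 hydrogen-bond donors and 0 hydrogen-bond acceptors, whereas 4-hydroxyphenyl brings 1 hydrogen-bond donor and 1 hydrogen-bond acceptor and also carries its substituent at a different ring carbon, and this larger change still leaves no readable difference at this position. No measurement at hand offers an explanation for this flat result.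

From the compounds shown here alone, all four compounds share the same core and chain, so it remains open whether an amine or a carboxylic acid on the ring, a plain alkyl group in place of the ring, or a longer chain would shift this assay beyond its scatter. A 3-hydroxyphenyl group would also help separate the effect of the new hydroxyl from that of its place on the ring.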